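Opening the ring of compound 2 in a growth test

The source may report more compounds than this note shows. Statements on the series, on what has been measured and on what is new or still open speak of the compounds shown alone.

In a functional assay on KB cells (Homo sapiens) for inhibition, read by MTT assay, with a stated time of 24 h, tested at 1 ug/mL (a higher number here means more inhibition of growth at the concentration tested, a lower number less inhibition of growth), the measured compounds gave
compound 1 (`O=C(CCCCC1CCSS1)Nc1ccccc1Cl`) - "not active" (no number reported)
compound 2 (`O=C(CCCCC1CCSS1)Nc1ccc(OC(F)(F)F)cc1`) - 1.54%
compound 3 (`O=C(CCCCC1CCSS1)Nc1cccc2ccccc12`) - 8.37%

Compound 2 and compound 3 lie within the scatter of each other, and compound 1 was reported without a number. Compound 2 therefore has no place of its own on the numbers shown, and it shares its standing with compound 3.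

Compound 4 (`O=C(CCCCC(S)CCS)Nc1ccc(OC(F)(F)F)cc1`) has not yet been measured in this assay. It differs from compound 2 in one place (a group of 5 heavy atoms (3 carbon, 2 sulfur; no ring) in place of a group of 5 heavy atoms (3 carbon, 2 sulfur; one five-membered non-aromatic ring with 2 hetero atoms), on a saturated chain carbon, four bonds along the chain from a carbonyl carbon) . The open 1,3-disulfanylpropyl group of compound 4 thus stands where compound 2 carries its ring, on the same saturated chain carbon.

Among the measured compounds shown here, no pair of measured compounds differs in one place only, and all three keep the ring, so the data do not show what opening it does. The expectation therefore starts from compound 2 (1.54%) and assumes no change beyond the scatter, with a slight rise at most. The expected size of the change is small (a number 4.5 percentage points higher from compound 2 to compound 4 (within the scatter)) . The estimated value for compound 4 is 6%, with an expected range from 0% to 20%.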

Compound 4, percent growth inhibition at one concentration: 6%
Beside the measured number, compound 4's estimate shows no gap at the digits printed; low and high end bracket the measured number.
By their numbers in this assay, from the lowest: compounds 2, 4 and 3 (each within the scatter of the next).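

Among the compounds shown here, compound 4 gives the first reading at this position: in this assay, putting the open 1,3-disulfanylpropyl group in place of the five-membered ring, on a saturated chain carbon, four bonds along the chain from a carbonyl carbon, gives a number 4.5 percentage points higher from compound 2 to compound 4 (within the scatter). The earlier compounds shown here all kept the ring, so they could not show that, for this one pair, the ring can be given up without a step that clears the scatter, even though the entering group carries hydrogen-bond donors that the ring lacks. No measurement offered here accounts for this result.

The compounds shown leave open whether the same opening would read alike on the amide parts of compound 1 and compound 3, the only other amide parts here. They also leave open what other groups would do at this place, such as a carboxylic acid or an amine at the end of the chain, or a longer chain carrying the two sulfur atoms.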